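The source may report more compounds than this note shows. Statements on the series, on what has been measured and on what is new or still open speak of the compounds shown alone.

Within the data shown here, compound 1, `Nc1ccc(Nc2c(C(=O)NCc3ccc(F)cc3)nc(Br)c3cccnc23)cc1`, is the only member of the series with a number attached. In a functional assay on MCF7 cells (Homo sapiens) for cytotoxicity, read by MTT assay, with a stated time of 72 h (on this read-out higher numbers stand for weaker inhibition and lower numbers for stronger inhibition), compound 1 gives 4000 nM. Two further analogues carry no result: compound 2, `COc1cccc(CNC(=O)c2nc(Br)c3cccnc3c2N[C@H]2CC[C@H](N)CC2)c1`, stands at "not determined" (no result reported) in this assay, and compound 3, `C[C@H](NC(=O)c1nc(Br)c2cccnc2c1N[C@H]1CC[C@H](N)CC1)c1ccc(F)cc1`, likewise at "not determined" (no result reported). Among the measured compounds shown here, with no second number, no step between measured compounds can be drawn, and compound 1 serves only as the single reference point.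

Compound 4, `NCCNc1c(C(=O)NCc2ccc(F)cc2)nc(Br)c2cccnc12`, is the next entry to be read. Its change from compound 1 is 2-aminoethyl in place of 4-aminophenyl on a nitrogen on an aromatic ring. The group that leaves is a ring; the group that enters is a short chain with no ring, on the same nitrogen on an aromatic ring whose other neighbours are aromatic carbon. Nothing in the series shows how this position responds, so the expectation is a step of modest size at most, toward weaker inhibition, and it may well stay within the usual scatter.

The step from compound 1 to compound 4 is estimated as a 1.5-fold higher number from compound 1 to compound 4 (0.18 log units; within the scatter) in this assay. For compound 4 the expected value in this assay is 6000 nM, with a range from 2000 nM to 20000 nM.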

Compound 4, half-maximal inhibitory concentration: 6000 nM
Compound 4: middle estimate and measured number agree at the digits printed, within the range that was stated.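

In this assay the nitrogen on an aromatic ring now has its first reading: 2-aminoethyl in place of 4-aminophenyl gives a 1.5-fold higher number from compound 1 to compound 4 (0.18 log units; within the scatter). For this one pair, the six-membered aromatic ring of 4-aminophenyl can give way to a short chain with no ring without a step beyond the scatter, and both groups carry an amine. No accompanying measurement bears on this result, so the pair records the read-out and offers no explanation for it.

From the compounds shown here alone, whether a longer chain holds the same reading at this nitrogen remains open, as does the outcome of a carboxylic acid in place of the amine of 2-aminoethyl. A single pair also cannot show whether this result carries over to other groups elsewhere on the shared core.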